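This account rests on a few compounds, and the source may have more. Where it says the series, first, only, none or still open, it means among the compounds named here.

Compound 3, `C(=C/c1nn2c(-c3ccccc3)nnc2s1)\c1ccco1`, is the reference point of this series. In an assay for inhibition of histone-lysine N-methyltransferase, H3 lysine-79 specific (Homo sapiens), read by scintillation counting, with stated times of 15 min and 60 min, tested at 100 uM, in the presence of a further agent that is not named here (a lower number here means a weaker effect, a higher number a stronger effect of the compound at the concentration tested), compound 3 gives 81%, which is the highest of the three numbers measured. The two fluorinated relatives sit well beneath it: compound 1, `Fc1ccc(-c2nnc3sc(/C=C/c4ccco4)nn23)cc1`, gives 40% in this assay, and compound 2, `Fc1cccc(-c2nnc3sc(/C=C/c4ccco4)nn23)c1`, gives 29%. The steps are a number 41 percentage points higher from compound 1 to compound 3 (beyond the scatter) and a number 52 percentage points higher from compound 2 to compound 3 (beyond the scatter), while between the two fluorinated compounds there is a number 11 percentage points lower from compound 1 to compound 2 (beyond the scatter).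

Compound 4 is `CN(C)c1ccc(-c2nnc3sc(/C=C/c4ccco4)nn23)cc1`, and it differs from compound 3 in one place: dimethylamino in place of hydrogen on an aromatic carbon. Among the compounds with values here, the steps that bear on this are the two that swap hydrogen for fluoro on the same ring, both large and both in the direction of a weaker effect when a substituent is present. Dimethylamino is a larger group than fluoro and has not been tried here, so the size of its step is uncertain; nevertheless the available evidence points downward. A step of a number 26 percentage points lower from compound 3 to compound 4 (beyond the scatter) is therefore expected, beyond the scatter, giving compound 4 an estimated 55% in this assay, within a range from 25% to 85%.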

Compound 4, a percentage reported as inhibition, at one concentration (the size of the read-out at that concentration, not a potency): 73%
Beside the measured number, compound 4's estimate is 18 percentage points below it, and the stated range covers the measured number.
By their numbers in this assay, from the lowest: compound 2; then compound 1; then compounds 4 and 3 (each within the scatter of the next).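

The step of a number 8 percentage points lower from compound 3 to compound 4 (within the scatter) in this assay shows that a group on this aromatic carbon, para to a large group, does not have to go with the large steps seen for fluoro. Compound 4 goes against any reading of compounds 1 and 3 as a rule that a substituent at this place costs effect, and the step of a number 33 percentage points higher from compound 1 to compound 4 (beyond the scatter) shows that the outcome here depends on which group is present, since dimethylamino and fluoro are clearly separated at the same carbon. The data offer no measured property that would explain this difference between the two groups.

What the compounds shown leave open is whether other groups at this place, such as a primary amine, a methoxy group or a carboxylic acid, would stay with dimethylamino or fall with fluoro, and whether a longer chain on the nitrogen would be accommodated as well. As far as these compounds go, it also remains open how dimethylamino would behave on the ring carbon that carries fluoro in compound 2, and, with a single tested concentration, how the effects of compound 3 and compound 4 compare at any other concentration.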